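The compounds below may be only part of what the source reports. "The series", "measured", "known", "first", "only" and "open" are said of these compounds alone.

Compound 1 `CCNC(=O)/C=C/C=C/[C@H](O)Cc1ccc(OC)c(OC)c1`: 13800 nM
Compound 2 `COc1ccc(C[C@@H](O)/C=C/C=C/C(=O)N2CCCCC2)cc1OC`: 16400 nM

Of the compounds shown here, two have been measured in a functional assay on A549 cells (Homo sapiens) for antiproliferative activity, read by sulforhodamine B assay, with a stated time of 48 h; a lower number here means a stronger inhibitor, a higher number a weaker inhibitor. Compound 1 gives 13800 nM, and compound 2 gives 16400 nM. Of the two numbers, that of compound 2 is the larger on paper, but the step of a 1.2-fold higher number from compound 1 to compound 2 (0.07 log units; within the scatter) lies within the scatter, so the two compounds are not distinguished by this assay.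

Compound 3 `COc1ccc(C[C@@H](O)/C=C/C=C/C(=O)NCc2ccc(Cl)cc2)cc1OC` has not yet been measured. It differs from compound 2 by (4-chlorobenzyl)amino in place of piperidin-1-yl on a carbonyl carbon. Going by the values given here, only one measured step bears on this change: the exchange of ethylamino for piperidin-1-yl on the same carbonyl carbon, which produced a 1.2-fold higher number from compound 1 to compound 2 (0.07 log units; within the scatter), a step within the scatter. Among the compounds with values here, no measured compound carries a (4-chlorobenzyl)amino group, so the expectation rests on that single step alone.

Compound 3 is therefore expected to stay close to compound 2 in this assay, with an estimated step of a 1.4-fold lower number from compound 2 to compound 3 (0.14 log units; within the scatter) that is not clearly beyond the scatter. Compound 3 is estimated at 12000 nM, with a range from 4000 nM to 40000 nM.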

Compound 3, half-maximal inhibitory concentration: 16500 nM
Estimate against measurement, compound 3: 1.4-fold (0.14 log units) below; the measured number falls inside the stated range.
By their numbers in this assay, from the lowest: compounds 1, 2 and 3 (each within the scatter of the next).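

In this assay the carbonyl carbon now carries a third kind of substituent: the exchange of piperidin-1-yl for (4-chlorobenzyl)amino gives a 1.0-fold higher number from compound 2 to compound 3 (0.00 log units; within the scatter) and the exchange of methyl for 4-chlorophenyl on the saturated chain carbon bound to the amide-type nitrogen gives a 1.2-fold higher number from compound 1 to compound 3 (0.08 log units; within the scatter) in the same assay. The earlier step compared only ethylamino with piperidin-1-yl, whereas the three compounds now span a six-membered non-aromatic ring and a six-membered aromatic ring of carbon only, with and without the amide hydrogen, and this read-out does not distinguish any of them. Nothing in the data shown explains why these exchanges leave the numbers within the scatter.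

As far as these compounds go, whether any group on this carbonyl carbon can move the number beyond the scatter stays open, as does the part played by the chlorine, which a plain benzylamino group or a carboxylic acid in place of the amide would begin to address. The three compounds also share the rest of the core, so they say nothing about a change made away from this carbonyl carbon.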